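Moving methoxy groups on a trimethoxyphenyl ring

The source may report more compounds than this note shows. Statements on the series, on what has been measured and on what is new or still open speak of the compounds shown alone.

Measured so far:
Compound 1 `Cc1ccc(S(=O)(=O)N(Cc2ccccc2)Cc2cccc(F)c2F)cc1`: -35.7%
Compound 2 `COc1cc(OC)c(Cn2cc(CN(Cc3cn(S(=O)(=O)c4ccc(C)cc4)c4ccccc34)S(=O)(=O)c3ccc(C)cc3)nn2)c(OC)c1`: -22%

In a functional assay on 3T3-L1 cells (Mus musculus) for inhibition, with a stated time of 20 min, tested at 20 uM (a lower number here means less inhibition, a higher number more inhibition at the concentration tested (going by the name of the read-out)), compound 2 gives -22%, the higher of the two numbers; compound 1 lies lower by a gap beyond the usual scatter. Compound 3 `COc1ccc(Cn2cc(CN(Cc3cn(S(=O)(=O)c4ccc(C)cc4)c4ccccc34)S(=O)(=O)c3ccc(C)cc3)nn2)c(OC)c1OC` keeps every atom of compound 2 but joins them differently: 2,3,4-trimethoxyphenyl in place of 2,4,6-trimethoxyphenyl on a saturated chain carbon bound to an aromatic nitrogen. Among the measured compounds shown here, with no measured pair showing what such a rearrangement does, the step from compound 2 to compound 3 is expected to stay within the scatter, no change at the digits printed from compound 2 to compound 3 (within the scatter). Compound 3 is therefore estimated at -22%, with a range from -45% to 0%.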

Compound 3, a percentage reported as inhibition, at one concentration (the size of the read-out at that concentration, not a potency): -18%
For compound 3 the middle estimate is 4 percentage points below the measured one; the range from low to high includes it.
By their numbers in this assay, from the lowest: compound 1; then compounds 2 and 3 (each within the scatter of the next).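

In this assay, 2,3,4-trimethoxyphenyl in place of 2,4,6-trimethoxyphenyl on a saturated chain carbon bound to an aromatic nitrogen gives a number 4 percentage points higher from compound 2 to compound 3 (within the scatter). Among the compounds shown here, this is the first measured pair at this place, and it shows that this rearrangement of the methoxy groups, with the same atoms kept, does not separate the two compounds in this read-out. Nothing available offers an explanation for this result. Still open, from the compounds shown here alone, is whether an amine or a carboxylic acid on this ring, in place of a methoxy group, would shift the number beyond the scatter.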